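This account rests on a few compounds, and the source may have more. Where it says the series, first, only, none or still open, it means among the compounds named here.

Compound 1 `NC(=O)CC[C@H](NC(=O)CN(c1ncnc2c1ncn2C1CCCCO1)C1CC1)C(=O)OCc1ccccc1` gives 47% in a functional assay on the whole organism (Tail, strain ICR) with Mus musculus as the target, in the tail flick test, with a stated time of 30 min, at a dose of 25 umol/kg by the oral route (a lower number here means a weaker effect, a higher number a stronger effect of the compound at the dose given), and stands highest of the three numbers measured, beyond the scatter above both others. Within the data shown here, compound 2 `C[C@@H](O)[C@H](NC(=O)CN(c1nc(Cl)nc2[nH]cnc12)C1CC1)C(=O)OCc1ccccc1` gives 21.9% in this assay, and compound 3 `C[C@@H](O)[C@H](NC(=O)CN(c1nc(Cl)nc2[nH]cnc12)C1CC1)C(=O)O` gives 18.6%; the step of a number 3.3 percentage points lower from compound 2 to compound 3 (within the scatter) is the only measured single change. Compound 4 `C[C@H](NC(=O)CN(c1ncnc2c1ncn2C1CCCCO1)C1CC1)C(=O)OCc1ccccc1` differs from compound 1 by hydrogen in place of carbamoylmethyl on a saturated chain carbon, two bonds along the chain from an amide-type nitrogen and a carbonyl carbon. Among the measured compounds shown here, the measured step concerns a different position and a different core, so no measured step bears directly on this change; removal of a group of this size is untested here. Compound 4 is expected to give 35%, within 15% to 55%. The expected step of a number 12 percentage points lower from compound 1 to compound 4 (beyond the scatter) is a moderate lowering, not firmly beyond the scatter.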

Compound 4, a percentage reported as activity, at one dose (the size of the read-out at that dose, not a potency): 55.9%
Estimate against measurement, compound 4: 20.9 percentage points below; the whole stated range lies below it.
By their numbers in this assay, from the lowest: compounds 3 and 2 (each within the scatter of the next); then compounds 1 and 4 (each within the scatter of the next).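

In this assay, hydrogen in place of carbamoylmethyl on this saturated chain carbon gives a number 8.9 percentage points higher from compound 1 to compound 4 (within the scatter). For this pair on the shared core, the read-out at this dose therefore does not depend on carbamoylmethyl at this place, which the earlier step, at a different position on a different core, could not show. No available evidence explains this result. Open, from the compounds shown here alone, is how a carboxylic acid, an amine or a longer chain at this carbon would read. Also open, going by these compounds, is whether the same exchange reads alike on the core of compound 2.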